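The source may hold more compounds than are shown below. What is called first, only, known or untested is meant among the compounds shown, and "the series" means these compounds.

Measured so far:
compound 1 `COc1cc(-c2nnc(SCc3cccc([N+](=O)[O-])c3)o2)ccc1O` gives 16000 nM
compound 2 `COc1cccc(CSc2nnc(-c3ccc(O)c(OC)c3)o2)c1` gives 7410 nM

Both numbers come from a functional assay on cells (T-cell, Mus musculus, strain BALB/c) for inhibition, read by MTT assay, with stated times of 24 h and 72 h; a lower number here means a stronger inhibitor, a higher number a weaker inhibitor. Of the two, compound 1 carries the higher one; its nearest neighbour is compound 2, reached by a 2.2-fold lower number from compound 1 to compound 2 (0.33 log units; beyond the scatter), a change of methoxy in place of nitro on an aromatic carbon.

Compound 3 `COc1cc(-c2nnc(SCc3cccc([N+](=O)[O-])c3)o2)ccc1OCc1cccc([N+](=O)[O-])c1` has not yet been measured. It differs from compound 1 in a single place: 3-nitrobenzyl in place of hydrogen on an oxygen on an aromatic ring. Among the measured compounds shown here, the only measured step concerns a different part of the shared core and leaves the hydroxy untouched, so it offers no direct guide to capping that hydroxy with 3-nitrobenzyl. For the measured compounds named here, no measured pair shows what such a cap does here.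

For compound 3 the expectation is therefore a number close to that of compound 1, with wide uncertainty on both sides. The step of no change at the digits printed from compound 1 to compound 3 (within the scatter) is estimated to stay within the scatter. The estimate for compound 3 is 16000 nM, between 5000 nM and 50000 nM.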

Compound 3, half-maximal inhibitory concentration: 12200 nM
For compound 3 the middle estimate is 1.3-fold (0.12 log units) above the measured one; the measured number falls inside the stated range.
By their numbers in this assay, from the lowest: compounds 2, 3 and 1 (each within the scatter of the next, the first and the last beyond it).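

In this assay, the 3-nitrobenzyl in place of hydrogen on the oxygen on the aromatic ring gives a 1.3-fold lower number from compound 1 to compound 3 (0.12 log units; within the scatter), so this large addition leaves the number within the usual scatter. This pair therefore shows that, at this micromolar level of activity, the free hydroxy is not needed to keep the reading, and that the position accepts a whole extra aromatic ring without a clear loss or gain. No other measurement here offers an explanation for this outcome.

On these data alone, it remains open whether a small methyl on this oxygen, an unsubstituted benzyl, or a longer chain ending in an amine or a carboxylic acid would read the same. Also open, as far as these compounds go, is whether 3-nitrobenzyl on this oxygen would behave the same way with the methoxy of compound 2 in place of the nitro.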